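Swapping Methoxy for Fluoro on the Benzyl Ring

The source may report more compounds than this note shows. Statements on the series, on what has been measured and on what is new or still open speak of the compounds shown alone.

Measured compounds:
- compound 1 `CCCCCCCC/N=c1\nc(N)c2ncn(Cc3ccccc3)c2c(N)n1`: 4750 nM
- compound 2 `CCCCCCCC/N=c1\nc(N)c2ncn(Cc3ccc(OC)cc3)c2c(N)n1`: 2550 nM

Both compounds share one core and differ only in the group on the benzyl ring. In a functional assay on MDA-MB-231 cells (Homo sapiens) for antiproliferative activity, read by WST assay, with a stated time of 72 h (a higher number here means a weaker inhibitor, a lower number a stronger inhibitor), compound 1 gives 4750 nM, and compound 2 gives 2550 nM. Within the data shown here, the one measured step, a 1.9-fold lower number from compound 1 to compound 2 (0.27 log units; within the scatter), falls within the scatter, so compound 2 cannot be told apart from compound 1 on these numbers.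

Compound 3 `CCCCCCCC/N=c1\nc(N)c2ncn(Cc3ccc(F)cc3)c2c(N)n1` takes the next step: fluoro in place of methoxy on an aromatic carbon. Among the measured compounds shown here, no measured pair shows this exact change; the only step known, from hydrogen to methoxy, was small, so the para position appears to tolerate a small group without much effect. The expectation is therefore a step of a 1.3-fold higher number from compound 2 to compound 3 (0.10 log units; within the scatter), none beyond the scatter. Compound 3 is estimated at 3200 nM, in the range 1500 nM to 7000 nM.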

Compound 3, half-maximal inhibitory concentration: 3600 nM
Compound 3: the middle estimate sits 1.1-fold (0.05 log units) below what was measured; low and high end bracket the measured number.
By their numbers in this assay, from the lowest: compounds 2, 3 and 1 (each within the scatter of the next).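

In this assay fluoro in place of methoxy gives a 1.4-fold higher number from compound 2 to compound 3 (0.15 log units; within the scatter) and fluoro in place of hydrogen gives a 1.3-fold lower number from compound 1 to compound 3 (0.12 log units; within the scatter) on the same aromatic carbon. This position has now carried hydrogen, methoxy and fluoro, and compounds 1, 2 and 3 cannot be told apart on these numbers, so a second small group has joined methoxy without a step beyond the scatter. There is no evidence here that explains why these three groups give such similar numbers.

Still open, going by these compounds, is whether a different kind of group at this spot, such as an amine or a carboxylic acid, would produce a step beyond the scatter. Also open, on these data alone, is whether fluoro or methoxy on another carbon of this ring would give similar numbers.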